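Replacing a nitrophenyl by a dichlorophenyl on the ring nitrogen

The compounds below may be only part of what the source reports. "The series", "measured", "known", "first", "only" and "open" are said of these compounds alone.

Of the compounds shown here, three built on one shared core have been tested in an ADME assay on L02 cells (Homo sapiens) for antiproliferative activity, read by MTT assay, with a stated time of 48 h; on this read-out lower numbers stand for stronger inhibition and higher numbers for weaker inhibition. Compound 1 `N#CC1=C(N)Oc2c(c3nc4ccccc4nc3c3ccccc23)C12C(=O)N(Cc1cnnn1-c1ccc(Cl)cc1)c1ccccc12` carries a 4-chlorophenyl on an aromatic nitrogen; in this assay compound 1 gives > 50000 nM, which is a limit of the assay and not a number. Compound 2 `N#CC1=C(N)Oc2c(c3nc4ccccc4nc3c3ccccc23)C12C(=O)N(Cc1cnnn1-c1cccc(Cl)c1)c1ccccc12` carries a 3-chlorophenyl in that position, and in this assay compound 2 gives 35200 nM. Compound 3 `N#CC1=C(N)Oc2c(c3nc4ccccc4nc3c3ccccc23)C12C(=O)N(Cc1cnnn1-c1ccc([N+](=O)[O-])cc1)c1ccccc12` carries a 4-nitrophenyl; in this assay compound 3 gives > 50000 nM, again a limit rather than a number. Compound 3 therefore stands at the limit of > 50000 nM in this assay, at which 2 of the 3 values shown sit, the weakest end of what the assay can report.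

The measured steps are all small: an at least 1.4-fold lower number from compound 1 to compound 2 (0.15 log units; that floor lies within the scatter), an at least 1.4-fold higher number from compound 2 to compound 3 (0.15 log units; that floor lies within the scatter), and a step that the two limits leave unreadable from compound 1 to compound 3.

Compound 4 `N#CC1=C(N)Oc2c(c3nc4ccccc4nc3c3ccccc23)C12C(=O)N(Cc1cnnn1-c1cc(Cl)ccc1Cl)c1ccccc12` differs from compound 3 in one place: 2,5-dichlorophenyl in place of 4-nitrophenyl on an aromatic nitrogen. The two steps that bear on this change, the move of a chloro around the ring from compound 1 to compound 2 and the exchange of nitro for chloro from compound 2 to compound 3, both sit within the scatter. No step beyond the scatter is therefore expected in this assay for compound 4. Compound 4 is estimated at 45000 nM, with a range from 20000 nM to 100000 nM, which means an expected at least 1.1-fold lower number from compound 3 to compound 4 (0.04 log units; that floor lies within the scatter).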

Compound 4, half-maximal inhibitory concentration: > 50000 nM
Compound 4 gave a limit, no number; the forecaster's own chance of this, stated with the estimate: 55%; middle value at least 1.1-fold (0.04 log units) away from the limit.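

In this assay, putting chloro in place of hydrogen on an aromatic carbon of the ring on this nitrogen gives an at least 1.4-fold higher number from compound 2 to compound 4 (0.15 log units; that floor lies within the scatter), so only a floor on the size of this step is known. The steps that join the other two compounds to compound 4 cannot be read, as both ends of each are limits. Compound 4 gives a limit and not a number, so a ring with two chloro groups now joins the 4-chlorophenyl and the 4-nitrophenyl at the same edge of the assay, and compound 2 remains the one exception: the limit of > 50000 nM in this assay, at which 3 of the 4 values shown sit.

Compound 2 is the only one of these compounds to give a number, 35200 nM. As far as these compounds go, how far the other three lie past the limit stays unknown. Also open, from the compounds shown here alone, is whether an amine or a carboxylic acid on the phenyl ring, or a longer chain in place of that ring, would move the read-out by more than the usual scatter.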